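From octyloxy to benzyloxy on a shared core

This account rests on a few compounds, and the source may have more. Where it says the series, first, only, none or still open, it means among the compounds named here.

Values in an ADME assay on BCBL1 cells (Homo sapiens) for cytotoxicity, with a stated time of 7 days; a lower number here means that less compound is tolerated, a higher number that more compound is tolerated:
Compound 1 `CNc1nc(N)nc2c1ncn2/C=C1/CC1(CO)CO`: 67000 nM
Compound 2 `CC(C)CSc1nc(N)nc2c1ncn2/C=C1/CC1(CO)CO`: > 20000 nM (a limit)
Compound 3 `CCCCCCCCOc1nc(N)nc2c1ncn2/C=C1/CC1(CO)CO`: > 20000 nM (a limit)

Compound 3 has no number in this assay, only a limit, and it shares that position with compound 2: the limit of > 20000 nM in this assay, at which 2 of the 3 values shown sit. Compound 4 `Nc1nc(OCc2ccccc2)c2ncn(/C=C3/CC3(CO)CO)c2n1` differs from compound 3 in one place, (phenyl in place of heptyl on a saturated chain carbon bound to an oxygen on an aromatic ring), which turns octyloxy into benzyloxy. The measured steps that bear on this change are a step that the limit leaves unreadable from compound 1 to compound 3 and a step that the two limits leave unreadable from compound 2 to compound 3, so neither offers a size to carry over. No step beyond the scatter is therefore expected in either direction, and the expected step that the limit leaves unreadable from compound 3 to compound 4 is only a rough guide. Compound 4 is estimated at 40000 nM, with an expected range from 15000 nM to 100000 nM.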

Compound 4, half-maximal cytotoxic concentration: > 20000 nM
Compound 4 ended at the assay's limit (the forecaster's own chance of this, stated with the estimate: 70%); the middle value does not contradict the limit.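

In this assay compound 4 gives only a limit, so its steps from compound 1, compound 2 and compound 3 cannot be read: the limit of > 20000 nM in this assay, at which 3 of the 4 values shown sit. The compounds shown leave open how far compound 2, compound 3 and compound 4 differ from one another or from compound 1.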